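This account rests on a few compounds, and the source may have more. Where it says the series, first, only, none or still open, it means among the compounds named here.

For the measured compounds named here, compound 2 `O=C(/C=C\Nc1ccc2[nH]ccc2c1)c1nc(-c2ccc(C(F)(F)F)cc2)n2ccccc12` is the only member of this small set with a measured number: in a functional assay on BT-474 cells (Homo sapiens) for cytotoxicity, read by MTT assay, with a stated time of 48 h (on this read-out lower numbers stand for stronger inhibition and higher numbers for weaker inhibition), compound 2 gives 5190 nM. Its neighbour compound 1 `O=C(/C=C\Nc1ccc2cc[nH]c2c1)c1nc(-c2ccc(C(F)(F)F)cc2)n2ccccc12` carries 1H-indol-6-yl on the amine nitrogen instead. In this assay compound 1 gives > 30000 nM, which is a limit of the assay and not a number; this is the limit of > 30000 nM in this assay, at which 1 of the 2 values shown sits. Going by the values given here, the one measured step, an at least 5.7-fold lower number from compound 1 to compound 2 (0.76 log units; beyond the scatter), shows that the 1H-indol-5-yl arrangement is the stronger of the two indoles.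

Compound 3 `O=C(/C=C\Nc1ccc(F)cc1)c1nc(-c2ccc(C(F)(F)F)cc2)n2ccccc12` drops the indole altogether: 4-fluorophenyl in place of 1H-indol-5-yl on an amine nitrogen. Among the compounds with values here, no measured step covers the removal of the indole, and compound 3 does without the hydrogen-bond donor that both measured compounds carry. Within the data shown here, the only guidance is that shifting the indole from one arrangement to the other already cost a modest amount, so the step is expected to weaken inhibition, with a fair chance that only a limit is reported. The expected step is a 2.9-fold higher number from compound 2 to compound 3 (0.46 log units; beyond the scatter). Compound 3 is estimated at 15000 nM in this assay, with a range from 4000 nM to 50000 nM.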

Compound 3, half-maximal inhibitory concentration: > 30000 nM
Compound 3 ended at the assay's limit (the forecaster's own chance of this, stated with the estimate: 30%); middle value at least 2.0-fold (0.30 log units) from the limit.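

In this assay, 4-fluorophenyl in place of 1H-indol-5-yl on the amine nitrogen gives an at least 5.7-fold higher number from compound 2 to compound 3 (0.76 log units; beyond the scatter), so a simple phenyl ring carrying fluorine does not keep the measurable activity of compound 2. The earlier pair had shown only that the indole's arrangement matters, whereas this step shows that the 1H-indol-5-yl group cannot be swapped for this smaller single ring without a loss beyond the scatter. The value of compound 3 is a limit of the assay and not a number, like that of compound 1, so the step between these two cannot be read, and compound 2 remains the only one of the three with a number: the limit of > 30000 nM in this assay, at which 2 of the 3 values shown sit.

The change removes the five-membered ring and the hydrogen-bond donor and adds a fluorine in a single step, and the compounds shown do not separate these three differences. On these data alone, it remains open whether a group such as 4-hydroxyphenyl, 4-aminophenyl or 1H-benzimidazol-5-yl on the amine nitrogen would bring back a measurable value.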